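The source may report more compounds than this note shows. Statements on the series, on what has been measured and on what is new or still open speak of the compounds shown alone.

Measured in a physicochemical assay for lipophilicity; on this read-out lower numbers stand for lower lipophilicity and higher numbers for higher lipophilicity:
Compound 1 `COc1c(OC)c(OC(=O)C(C)C)c2cc(Cl)ccc2c1OC(=O)C(C)C`: 5.4
Compound 2 `COc1c(OC)c(OC(=O)C(C)(C)C)c2cc(Cl)ccc2c1OC(=O)C(C)(C)C`: 6.6
Compound 3 `CCC(=O)Oc1c(OC)c(OC)c(OC(=O)CC)c2c(OC)cccc12`: 3.44

Compound 2, at 6.6, stands highest of these three. The nearest is compound 1 at 5.4 and the furthest is compound 3 at 3.44, and both gaps lie beyond the scatter of this assay.

Compound 4 `COc1c(OC)c(OC(=O)C(C)(C)C)c2cc(C)ccc2c1OC(=O)C(C)(C)C` has yet to be measured. It carries methyl in place of chloro on an aromatic carbon of compound 2, and the rest of the structure is unchanged: methyl in place of chloro on an aromatic carbon. Among the compounds with values here, no two measured compounds differ in one place only, so the data offer no direct precedent for this exchange. The expectation therefore rests on the structural change alone, and it is for a small fall in this assay that probably stays within the scatter. The expected size of this change is a number 0.20 log units lower from compound 2 to compound 4 (within the scatter). For compound 4 the estimated value is 6.4, with an expected range from 6 to 6.8.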

Compound 4, partition coefficient: 6.1
Estimate against measurement, compound 4: 0.30 log units above; the measured number falls inside the stated range.
By their numbers in this assay, from the lowest: compound 3; then compound 1; then compound 4; then compound 2.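

In this assay, within the data shown here, methyl in place of chloro on this aromatic carbon, meta to a fused ring and para to a fused ring, gives a number 0.50 log units lower from compound 2 to compound 4 (beyond the scatter), a modest step and the first reading from a pair that differs in one place only. It shows that the number responds at this position even though chloro and methyl each count one heavy atom and neither carries a hydrogen-bond donor or acceptor. Nothing measured here accounts for the step.

As far as these compounds go, whether the same exchange gives a step of similar size on the core of compound 1, with its different ester groups, remains open. Also open, from the compounds shown here alone, is how fluoro, an amine or a carboxylic acid on this aromatic carbon would compare with chloro and methyl.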